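Chain extension on the amide nitrogen substituent

The source may report more compounds than this note shows. Statements on the series, on what has been measured and on what is new or still open speak of the compounds shown alone.

For the measured compounds named here, compound 2 `Cc1ccc(Sc2cnc(Nc3cccc(Br)n3)s2)cc1C(=O)N(C)CC#N` gives 2 nM in an assay on isolated protein for inhibition of high affinity nerve growth factor receptor (Homo sapiens) (a higher number here means a weaker inhibitor, a lower number a stronger inhibitor), and stands lowest of the two numbers so far; compound 1 `Cc1ccc(Sc2cnc(Nc3ccccn3)s2)cc1C(N)=O` gives 790 nM in this assay, a gap that lies beyond the scatter. Compound 3 `Cc1ccc(Sc2cnc(Nc3cccc(Br)n3)s2)cc1C(=O)N(C)CCC#N` differs from compound 2 in one place only: cyanomethyl in place of cyano on a saturated chain carbon bound to an amide-type nitrogen. Going by the values given here, no step between measured compounds covers this change, so its size is uncertain. The expected step is a 2.0-fold higher number from compound 2 to compound 3 (0.30 log units; within the scatter), small, toward a higher number, at or just beyond the scatter. Compound 3 is therefore estimated at 4 nM in this assay, with a range from 1 nM to 15 nM.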

Compound 3, half-maximal inhibitory concentration: 10 nM
Beside the measured number, compound 3's estimate is 2.5-fold (0.40 log units) below it, within the range that was stated.
By their numbers in this assay, from the lowest: compound 2; then compound 3; then compound 1.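

In this assay the move from cyanomethyl to 2-cyanoethyl on the saturated chain carbon bound to the amide-type nitrogen gives a 5.0-fold higher number from compound 2 to compound 3 (0.70 log units; beyond the scatter) and so counts as a modest loss. This position therefore responds to a single added chain carbon, with the nitrile kept in the group, though one pair defines no trend. Nothing available bears on the origin of this step. On these data alone, whether a longer chain such as 3-cyanopropyl extends the same direction remains open. So does the outcome of an amine or carboxylic acid at the chain end.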